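The source may report more compounds than this note shows. Statements on the series, on what has been measured and on what is new or still open speak of the compounds shown alone.

Compound 1 `COc1ccc(/C=N/c2c(C)n(C)n(-c3ccccc3)c2=O)cc1`: 575000000 nM
Compound 2 `COc1cc(/C=N/c2c(C)n(C)n(-c3ccccc3)c2=O)ccc1O`: 468000000 nM
Compound 3 `COc1cccc(/C=N/c2c(C)n(C)n(-c3ccccc3)c2=O)c1O`: 89100000 nM

These three compounds were tested in a functional assay on HCT-116 cells (Homo sapiens) for cytotoxicity, read by MTT assay, with a stated time of 72 h; on this read-out lower numbers stand for stronger inhibition and higher numbers for weaker inhibition. Compound 1 gives the highest number of the three; compound 2 lies close to it, within the scatter, while compound 3 gives a lower number, beyond the scatter. Compound 4 `Cc1c(/N=C/c2ccc(Cl)cc2)c(=O)n(-c2ccccc2)n1C` differs from compound 1 in one place: chloro in place of methoxy on an aromatic carbon. Going by the values given here, no measured pair shows the effect of such an exchange, so the size and direction of the step are open. A modest shift in either direction, or none beyond the scatter, is expected, so for compound 4 the expected step is a 1.4-fold lower number from compound 1 to compound 4 (0.16 log units; within the scatter). The estimate for compound 4 is 400000000 nM, in the range 100000000 nM to 1500000000 nM.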

Compound 4, half-maximal inhibitory concentration: 589000000 nM
For compound 4 the middle estimate is 1.5-fold (0.17 log units) below the measured one; measured number inside the range.
By their numbers in this assay, from the lowest: compound 3; then compounds 2, 1 and 4 (each within the scatter of the next).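

In this assay, chloro in place of methoxy gives a 1.0-fold higher number from compound 1 to compound 4 (0.01 log units; within the scatter) on this aromatic carbon, para to a large group, so this exchange does not separate the two groups here. Methoxy carries a hydrogen-bond acceptor and chloro does not, yet the two compounds read alike. Nothing available explains this result.

On these data alone, whether an amine, a carboxylic acid or a longer chain at this place would read the same remains open. So does whether chloro would read alike elsewhere on this ring.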